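This account rests on a few compounds, and the source may have more. Where it says the series, first, only, none or still open, it means among the compounds named here.

Compound 3 `O=C(Nc1cccc2[nH]ncc12)NC1CCOc2c(OC(F)(F)F)cccc21` gives 5 nM in a functional assay for antagonist activity at transient receptor potential cation channel subfamily V member 1 (Homo sapiens), read by calcium flux; on this read-out lower numbers stand for stronger inhibition and higher numbers for weaker inhibition. Compound 2 `O=C(Nc1cccc2[nH]ncc12)NC1CCOc2c1cccc2C(F)(F)F` gives 5 nM, and compound 1 `O=C(Nc1cccc2[nH]ncc12)N[C@@H]1CCOc2cc(C(F)(F)F)ccc21` gives 4 nM, so all three numbers lie within the scatter of one another and none stands apart. Among the compounds with values here, the only measured step, no change at the digits printed from compound 2 to compound 3 (within the scatter), came from putting trifluoromethoxy where trifluoromethyl had been. Compound 4 `O=C(Nc1cccc2[nH]ncc12)NC1CCOc2c1cccc2N1CCCCC1` differs from compound 3 in piperidin-1-yl in place of trifluoromethoxy on an aromatic carbon. Within the data shown here, that earlier exchange replaced one group without a ring by another, whereas here a six-membered ring enters, so no measured step speaks directly to this change and its size is open. Compound 4 is expected to give 20 nM, with a range from 4 nM to 100 nM. The expected step, a 4.0-fold higher number from compound 3 to compound 4 (0.60 log units; beyond the scatter), is therefore a modest loss.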

Compound 4, half-maximal inhibitory concentration: 16 nM
Compound 4: middle estimate off by 1.3-fold (0.10 log units), on the high side, and the stated range covers the measured number.
By their numbers in this assay, from the lowest: compounds 1, 2 and 3 (each within the scatter of the next); then compound 4.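

Trifluoromethoxy for trifluoromethyl had shown no measurable change, but in this assay a six-membered ring on this aromatic carbon does shift the number: a 3.2-fold higher number from compound 3 to compound 4 (0.51 log units; beyond the scatter) for piperidin-1-yl against trifluoromethoxy, and a 3.2-fold higher number from compound 2 to compound 4 (0.51 log units; beyond the scatter) against trifluoromethyl. The position therefore responds to what sits there, yet the loss from adding the ring is only modest. No measurement available here accounts for that loss. Going by these compounds, it remains open whether the ring itself or its nitrogen drives the step, and whether dimethylamino, an amine without a ring, or morpholin-4-yl would behave like piperidin-1-yl.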